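The source may report more compounds than this note shows. Statements on the series, on what has been measured and on what is new or still open speak of the compounds shown alone.

Working notes on the series.

Compound 1 `CC(c1ccc(-c2ccccc2)c(F)c1)c1nnc2n1N=C(c1ccc(Cl)cc1)CS2` is the starting point; in a functional assay on Huh-7 cells (Homo sapiens) for inhibition, read by sulforhodamine B assay, with a stated time of 72 h (a higher number here means a weaker inhibitor, a lower number a stronger inhibitor), compound 1 gives 3900 nM. Compound 2 `CC(c1ccc(-c2ccccc2)c(F)c1)c1nnc2n1N=C(c1ccc(OC(F)(F)F)cc1)CS2` differs from it in one place, and in this assay compound 2 gives 8400 nM; the change, trifluoromethoxy in place of chloro on an aromatic carbon, brings a 2.2-fold higher number from compound 1 to compound 2 (0.33 log units; beyond the scatter). Compound 3 `COc1ccc2cc(C(C)c3nnc4n3N=C(c3ccc(C(F)(F)F)cc3)CS4)ccc2c1` carries a different aryl at the other end of the core, and in this assay compound 3 gives 14800 nM. Compound 3 stands at the highest of the three numbers seen so far; its gap to compound 2 is within the scatter, while its gap to compound 1 is beyond it.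

Compound 4 `COc1ccc2cc(C(C)c3nnc4n3N=C(c3ccc(Cl)cc3Cl)CS4)ccc2c1` is the next member. Its difference from compound 3 is 2,4-dichlorophenyl in place of 4-(trifluoromethyl)phenyl on a carbon with a double bond to nitrogen. For the measured compounds named here, the only measured step that touches the same part of the core is the one from compound 1 to compound 2, which was modest; read in reverse, a chloro in place of a fluorinated group gave the lower number. That is a weak pointer, since here a second chlorine also enters and the other end of the core is that of compound 3, not of compound 1. A modest step down, or none beyond the scatter, is therefore expected in this assay for compound 4, as a 1.6-fold lower number from compound 3 to compound 4 (0.22 log units; within the scatter). The estimate for compound 4 in this assay is 9000 nM, between 3000 nM and 25000 nM.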

Compound 4, half-maximal inhibitory concentration: 10700 nM
Compound 4: the middle estimate sits 1.2-fold (0.08 log units) below what was measured; measured number inside the range.
By their numbers in this assay, from the lowest: compound 1; then compounds 2, 4 and 3 (each within the scatter of the next).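

At the carbon with a double bond to nitrogen, in this assay, replacing 4-(trifluoromethyl)phenyl with 2,4-dichlorophenyl gives a 1.4-fold lower number from compound 3 to compound 4 (0.14 log units; within the scatter). For the compounds shown here, this is the first reading at this position with the other end of the core held as in compound 3, and it shows that this exchange of substituted phenyl groups leaves the number within the scatter, whereas the earlier change at the same position, with the other end as in compound 1, gave a 2.2-fold higher number from compound 1 to compound 2 (0.33 log units; beyond the scatter). The two steps involve different groups and different ends of the core, so they show no general rule for this position, and no available measurement explains either result.

Going by these compounds, whether a group of another kind at this position, such as an amine or a carboxylic acid in place of the halogen-bearing substituents, would give a step beyond the scatter remains open. On these data alone, it also remains open whether 2,4-dichlorophenyl would give a similar number with the other end of the core as in compound 1.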